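A few compounds are considered here, and "the series" means these few. Any claim that something is new, unique, unknown or untested is made for them only; others in the source may bear on it.

Of the compounds shown here, two have so far been measured in an assay on membranes from brain for binding affinity to neutral cholesterol ester hydrolase 1 (Mus musculus), read by fluorescence, with stated times of 1 h and 30 min; on this read-out higher numbers stand for weaker inhibition and lower numbers for stronger inhibition. Compound 1, `O=C(NCc1ccc(OCc2ccccc2)cc1)n1cccn1`, is the smaller of the pair, an amide-linked member of the series. In this assay compound 1 gives > 100000 nM, which is a limit of the assay and not a measured number. Compound 2, `Cc1cnn(C(=O)N2CCCN(Cc3ccc(OCc4ccccc4)cc3)CC2)c1`, carries the same benzyloxy-benzyl piece on a larger saturated ring. In this assay compound 2 gives > 100000 nM, again a limit rather than a number. Compound 2 thus stands with no measured affinity of its own, only a ceiling.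

Compound 3, `O=C(N1CCCN(Cc2ccc(OCc3ccccc3)cc2)CC1)n1cccn1`, has not yet been measured. It differs from compound 2 by hydrogen in place of methyl on an aromatic carbon. For the measured compounds named here, no measured pair shows what this change does in this assay. The step from compound 2 to compound 3 is expected to be none beyond the scatter, a number no higher from compound 2 to compound 3 (the limit leaves the size open), because compound 2 already sits at the limit of > 100000 nM in this assay, at which 2 of the 2 values shown sit. Compound 3 is therefore expected to give 100000 nM, with an expected range from 30000 nM to 300000 nM.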

Compound 3, half-maximal inhibitory concentration: > 100000 nM
Compound 3 gave a limit, no number; the forecaster's own chance of this, stated with the estimate: 85%; the middle value sits exactly at the limit.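

In this assay compound 3 gives > 100000 nM, a limit of the assay and not a number. Compound 2 also stands at a limit, so no step can be read between compound 2 and compound 3. None of the compounds shown gives a measured number, which leaves open what swapping 4-methyl-1H-pyrazol-1-yl for 1H-pyrazol-1-yl does to affinity.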